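The compounds below may be only part of what the source reports. "The series", "measured", "known", "first", "only" and "open" are said of these compounds alone.

Measured in a functional assay on A2780 cells (Homo sapiens) for cytotoxicity, read by sulforhodamine B assay, with a stated time of 72 h; a higher number here means a weaker inhibitor, a lower number a stronger inhibitor:
- compound 1 `O=C(NCc1ccc(S(=O)(=O)c2cccc(C(F)(F)F)c2)cc1)N1Cc2ccncc2C1`: 2.7 nM
- compound 2 `O=C(NCc1ccc(S(=O)(=O)c2cncc(C(F)(F)F)c2)cc1)N1Cc2ccncc2C1`: 10 nM
- compound 3 `O=C(NCc1ccc(S(=O)(=O)C2CCC(F)(F)CC2)cc1)N1Cc2ccncc2C1`: 13 nM

Compound 3 stands at 13 nM. The gap to its nearest neighbour is a 1.3-fold higher number from compound 2 to compound 3 (0.11 log units; within the scatter), and the gap to its furthest is a 4.8-fold higher number from compound 1 to compound 3 (0.68 log units; beyond the scatter).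

Compound 4 `CN1CCC(S(=O)(=O)c2ccc(CNC(=O)N3Cc4ccncc4C3)cc2)CC1` keeps the rest of compound 3 and changes one group: 1-methylpiperidin-4-yl in place of 4,4-difluorocyclohexyl on a sulfonyl sulfur.

All three measured steps are swaps at this same place, and none is large. Besides the two above, there is a 3.7-fold higher number from compound 1 to compound 2 (0.57 log units; beyond the scatter). None of them brings in a non-aromatic ring holding a nitrogen, so the data give no direct guide to this swap and the direction remains uncertain. A modest move in this assay towards a higher number, meaning a weaker inhibitor, seems the likeliest outcome.

The expected change is a 2.3-fold higher number from compound 3 to compound 4 (0.36 log units; beyond the scatter).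

For compound 4 the estimate is 30 nM, with an expected range from 7 nM to 120 nM.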

Compound 4, half-maximal inhibitory concentration: 99 nM
Compound 4: middle estimate off by 3.3-fold (0.52 log units), on the low side; low and high end bracket the measured number.
By their numbers in this assay, from the lowest: compound 1; then compounds 2 and 3 (each within the scatter of the next); then compound 4.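

In this assay, 1-methylpiperidin-4-yl on the sulfonyl sulfur brings the first clear loss among non-aromatic groups at this place, with a 7.6-fold higher number from compound 3 to compound 4 (0.88 log units; beyond the scatter), and the gaps to the aromatic groups are wider still, with a 9.9-fold higher number from compound 2 to compound 4 (1.00 log units; beyond the scatter) and a 37-fold higher number from compound 1 to compound 4 (1.56 log units; beyond the scatter). Compound 4 is therefore the weakest of the four, and a six-membered non-aromatic ring at this place does not by itself secure a low number, since compound 3 also carries one. Nothing measured here explains this loss.

The compounds shown leave open whether the loss follows the ring nitrogen or its methyl group, which a piperidin-4-yl without the methyl or a tetrahydropyran-4-yl ring would help to separate. Also open, going by these compounds, is how an open-chain amine on the sulfonyl sulfur would compare.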